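This account rests on a few compounds, and the source may have more. Where it says the series, first, only, none or still open, it means among the compounds named here.

Measured so far in a functional assay on the whole organism (strain C57B/6) with Mus musculus as the target, in the maximal electroshock model; a lower number here means that less compound is needed, a higher number that more compound is needed for the effect:
- Compound 1 `CCCCCCCCCc1nncn1-c1ccc(OCCCCCC)cc1`: in this assay compound 1 gives > 40 mg/kg, which is a limit of the assay and not a number.
- Compound 2 `CCCCCCOc1ccc(-n2cnnc2-c2ccc(Cl)cc2)cc1`: in this assay compound 2 gives 19.7 mg/kg.

Among the compounds with values here, compound 2 thus holds the only number in this assay; the one further value shown is a limit (the limit of > 40 mg/kg in this assay, at which 1 of the 2 values shown sits). Within the data shown here, the single measured step, an at least 2.0-fold lower number from compound 1 to compound 2 (0.30 log units; that floor lies within the scatter), replaces nonyl with 4-chlorophenyl on an aromatic carbon, and its floor lies within the scatter. Compound 3 `CCCCCCOc1ccc(-n2cnnc2-c2ccc(OC)cc2)cc1` differs from compound 2 in another place: methoxy in place of chloro on an aromatic carbon. Among the measured compounds shown here, no measured step touches this exchange, so nothing in the data points to a step in this assay beyond the scatter in either direction. Compound 3 is therefore estimated to give 25 mg/kg, with a range from 10 mg/kg to 60 mg/kg. That estimate means an expected step of a 1.3-fold higher number from compound 2 to compound 3 (0.10 log units; within the scatter).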

Compound 3, dose for half-maximal effect: 15.8 mg/kg
Compound 3: middle estimate off by 1.6-fold (0.20 log units), on the high side; the measured number falls inside the stated range.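

In this assay, methoxy in place of chloro, on an aromatic carbon para to a large group, makes no change beyond the scatter: a 1.2-fold lower number from compound 2 to compound 3 (0.10 log units; within the scatter). The exchange of nonyl for 4-methoxyphenyl gives an at least 2.5-fold lower number from compound 1 to compound 3 (0.40 log units; beyond the scatter), a floor that lies beyond the scatter, unlike the floor of the exchange for 4-chlorophenyl. Compound 1 stands at a limit of the assay and not at a number, so this step is a floor only, and its true size cannot be read: the limit of > 40 mg/kg in this assay, at which 1 of the 3 values shown sits.

With only chloro and methoxy shown at this place, the compounds leave open how an amine or a carboxylic acid there would read in this assay. They also leave open what a shorter chain in place of nonyl would give, and whether an aryl group is needed at all for a measurable number.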